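The compounds below may be only part of what the source reports. "The series", "measured", "known", "first", "only" and "open" are said of these compounds alone.

Compound 1, `CCCNCc1ccccc1OCCCCCC(=O)OCC`, gives > 26000 nM in an ADME assay on Raji cells (Homo sapiens) for cytotoxicity, read by CellTiter-Glo and resazurin assay, with a stated time of 72 h (a higher number here means that more compound is needed for the effect, a lower number that less compound is needed), which is a limit of the assay.
Compound 2, `CCCNCc1cccc(OCCCCCC(=O)OCC)c1`, gives > 26000 nM in this assay, again a limit.
Compound 3, `CCOC(=O)CCCCCOc1ccccc1C=O`, gives > 26000 nM in this assay, also a limit.

Compound 1 and compound 2 have the same atoms joined differently; the difference between the two cores is not broken down here. Compound 3 differs from compound 1 by formyl in place of (propylamino)methyl on an aromatic carbon, and the step that the two limits leave unreadable from compound 1 to compound 3 cannot be read, since both values are limits. Compound 4, `CCOC(=O)CCCCCOc1cccc(C=O)c1`, differs from compound 2 by formyl in place of (propylamino)methyl on an aromatic carbon; this is the same kind of change, but here the place is meta to a large group rather than ortho to it. For compound 4 the step of a number no higher from compound 2 to compound 4 (the limit leaves the size open) is expected to be flat because every value shown sits at the limit of > 26000 nM in this assay, at which 3 of the 3 values shown sit. Compound 4 is therefore estimated at 26000 nM, most likely reported only as a limit.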

Compound 4, half-maximal effective concentration: > 26000 nM
Compound 4: a limit, no number; the forecaster's own chance of this, stated with the estimate: 85%; the middle value lies on the limit itself.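

Compound 2 and compound 4 each give a limit rather than a number in this assay, so the step between them cannot be read. The compounds shown leave open whether any structural difference among them changes the cytotoxicity: the limit of > 26000 nM in this assay, at which 4 of the 4 values shown sit.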